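The source may report more compounds than this note shows. Statements on the series, on what has been measured and on what is new or still open speak of the compounds shown alone.

Working notes on the series. In an ADME assay (liver) for metabolic stability, with Liver microsome (Rattus norvegicus) as the target, using microsomes and NADPH, with a stated time of 30 min, tested at 1 uM (on this read-out lower numbers stand for slow clearance and higher numbers for fast clearance), compound 1 `CS(=O)(=O)c1ccc(-c2cc(C(O)(C(F)(F)F)C(F)(F)F)cnc2N2CCN(S(=O)(=O)c3ccc(N)nc3)CC2)cc1` gives 103 mL.min-1.g-1 while compound 2 `Nc1ccc(S(=O)(=O)N2CCN(c3ncc(C(O)(C(F)(F)F)C(F)(F)F)cc3-c3ccc4ocnc4c3)CC2)cn1` gives 120 mL.min-1.g-1 and compound 3 `Cc1nc2cc(-c3cc(C(O)(C(F)(F)F)C(F)(F)F)cnc3N3CCN(S(=O)(=O)c4ccc(N)nc4)CC3)ccc2o1` gives 99 mL.min-1.g-1 on the shared core. Compound 3 thus stands with the other two, all three within the scatter of one another, so no order can be drawn among them.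

Compound 4 `Nc1ccc(S(=O)(=O)N2CCN(c3ncc(C(O)(C(F)(F)F)C(F)(F)F)cc3-c3ccc4c(c3)CC(=O)N4)CC2)cn1` keeps the shared core and changes one group, the 2-methyl-1,3-benzoxazol-5-yl of compound 3: a group of 10 heavy atoms (8 carbon, 1 nitrogen, 1 oxygen; one five-membered non-aromatic ring with 1 hetero atom, one six-membered aromatic ring of carbon only) in place of a group of 10 heavy atoms (8 carbon, 1 nitrogen, 1 oxygen; one five-membered aromatic ring with 2 hetero atoms, one six-membered aromatic ring of carbon only), on an aromatic carbon on a six-membered aromatic ring with 1 nitrogen.

Among the compounds with values here, three measured steps touch this same place: a 1.2-fold higher number from compound 1 to compound 2 (0.07 log units; within the scatter) then a 1.0-fold lower number from compound 1 to compound 3 (0.02 log units; within the scatter) and a 1.2-fold lower number from compound 2 to compound 3 (0.08 log units; within the scatter) in the same read-out. Each lies within the scatter, and together they cover three different groups at that carbon. Within the data shown here, none of the measured groups has a five-membered non-aromatic ring, so the data give no direction for this change, and the wide range below reflects that gap.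

The expected change is small and not beyond the scatter, an estimated 1.1-fold lower number from compound 3 to compound 4 (0.04 log units; within the scatter) on this read-out. Compound 4 is estimated at 90 mL.min-1.g-1 with an expected range from 45 mL.min-1.g-1 to 160 mL.min-1.g-1 on this read-out.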

Compound 4, intrinsic clearance in microsomes: 119 mL.min-1.g-1
Compound 4: the middle estimate sits 1.3-fold (0.12 log units) below what was measured; measured number inside the range.
By their numbers in this assay, from the lowest: compounds 3, 1, 4 and 2 (each within the scatter of the next).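

In this assay, within the data shown here, the first group at this carbon with a five-membered non-aromatic ring gives a 1.2-fold higher number from compound 3 to compound 4 (0.08 log units; within the scatter), and the same group gives a 1.0-fold lower number from compound 2 to compound 4 (0.00 log units; within the scatter) and a 1.2-fold higher number from compound 1 to compound 4 (0.06 log units; within the scatter), so all three new steps lie within the scatter. Swapping the five-membered aromatic ring with 2 hetero atoms for a five-membered non-aromatic ring with 1 hetero atom, with a double bond outside the aromatic rings and a hydrogen-bond donor entering, therefore produces no readable change on this read-out, and the four groups now measured at this carbon, ortho to a large group, cannot be put in any order. Nothing at hand gives a reason for this result.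

Still open is whether any group at this carbon can move the read-out beyond the scatter, for instance a small one such as a carboxylic acid or an open-chain amine in place of the groups shown. Also open, as far as these compounds go, is how the read-out responds to a change elsewhere on the shared core, as all four compounds keep the same 2,2,2-trifluoro-1-hydroxy-1-(trifluoromethyl)ethyl group.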